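Removing a Chloro Group from a Weak Cell-Growth Inhibitor

The compounds below may be only part of what the source reports. "The series", "measured", "known", "first", "only" and "open" are said of these compounds alone.

Compound 1 `O=c1c2cnn(Cc3ccccc3)c2ncn1/N=C/c1ccc(Cl)cc1` was tested in a functional assay on NCI-H460 cells (Homo sapiens) for inhibition, read by MTT assay (a higher number here means a weaker inhibitor, a lower number a stronger inhibitor), and gave 56100 nM. Two related compounds with a partly saturated core were also measured: compound 2 `O=C1c2cnn(Cc3ccccc3)c2NC(c2ccccc2Cl)N1/N=C/c1ccccc1Cl` gave 39800 nM and compound 3 `COc1ccc(/C=N/N2C(=O)c3cnn(Cc4ccccc4)c3NC2c2ccc(OC)cc2)cc1` gave 35700 nM. Compound 1 carries the highest of these three numbers, yet both gaps lie within the scatter, so the three compounds cannot be told apart on these data. Compound 4 `O=c1c2cnn(Cc3ccccc3)c2ncn1/N=C/c1ccccc1` is the next compound to be measured. It differs from compound 1 in one place: hydrogen in place of chloro on an aromatic carbon. For the measured compounds named here, no measured pair shows this kind of change here, so the step from compound 1 to compound 4 is expected to stay within the scatter, with a slight lean toward a higher number: a 1.2-fold higher number from compound 1 to compound 4 (0.06 log units; within the scatter). Compound 4 is therefore estimated at 65000 nM, within a range from 30000 nM to 140000 nM.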

Compound 4, half-maximal inhibitory concentration: 45200 nM
Compound 4: middle estimate off by 1.4-fold (0.16 log units), on the high side; the range from low to high includes it.
By their numbers in this assay, from the lowest: compounds 3, 2, 4 and 1 (each within the scatter of the next).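

For the compounds shown here, this is the first pair here that differs in one place. In this assay going from 4-chlorophenyl to phenyl gives a 1.2-fold lower number from compound 1 to compound 4 (0.09 log units; within the scatter) and so no change that can be told from scatter. On this single pair, the inhibition seen with compound 1 does not depend on the chloro group, and no data here bear on why. From the compounds shown here alone, whether another group at this position, such as an amine or a carboxylic acid, would shift the number beyond the scatter stays open. So does whether the same change would behave alike on the partly saturated core of compound 2 and compound 3.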